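Toward a chloropyridine amide on the shared benzothiazole-free core

This account rests on a few compounds, and the source may have more. Where it says the series, first, only, none or still open, it means among the compounds named here.

In an ADME assay for permeability, using PAMPA (a lower number here means that the compound crosses the layer more slowly, a higher number that the compound crosses the layer faster), the three measured compounds gave the following numbers:
compound 1, `C/C=C/C(=O)Nc1cccc(-c2nc3ccccc3s2)c1`: 1640 10^-6 cm/s
compound 2, `O=C(CCl)Nc1cccc(-c2nc3ccccc3s2)c1`: 660 10^-6 cm/s
compound 3, `CC(Cl)C(=O)Nc1cccc(-c2nc3ccccc3s2)c1`: 769 10^-6 cm/s

Compound 3 stands second highest of these three numbers. The step of a 1.2-fold higher number from compound 2 to compound 3 (0.07 log units; within the scatter) lies within the scatter, so compounds 2 and 3 cannot be told apart in this assay, while the step of a 2.1-fold lower number from compound 1 to compound 3 (0.33 log units; beyond the scatter) lies beyond it. The two steps that do reach beyond the scatter, a 2.5-fold lower number from compound 1 to compound 2 (0.40 log units; beyond the scatter) and a 2.1-fold lower number from compound 1 to compound 3 (0.33 log units; beyond the scatter), both exchange prop-1-en-1-yl on the carbonyl carbon for a chlorine-bearing saturated group, and both are modest.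

Compound 4, `O=C(Nc1cccc(-c2nc3ccccc3s2)c1)c1cnccc1Cl`, differs from compound 3 in one place: 4-chloropyridin-3-yl in place of 1-chloroethyl on a carbonyl carbon. Among the compounds with values here, no measured step exchanges a chain for an aromatic ring at this position, and none adds a hydrogen-bond acceptor, so the measured steps bear on this change only loosely. What they show is that changes on this carbonyl carbon have moved this assay by modest amounts at most, as in the steps of a 2.5-fold lower number from compound 1 to compound 2 (0.40 log units; beyond the scatter) and a 2.1-fold lower number from compound 1 to compound 3 (0.33 log units; beyond the scatter), and that a small enlargement left the number within the scatter, as in a 1.2-fold higher number from compound 2 to compound 3 (0.07 log units; within the scatter). Compound 4 is therefore expected to show a modest lower number, an estimated step of a 1.6-fold lower number from compound 3 to compound 4 (0.20 log units; within the scatter). For compound 4 the estimate in this assay is 480 10^-6 cm/s, with a range from 200 10^-6 cm/s to 1150 10^-6 cm/s.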

Compound 4, apparent permeability: 732 10^-6 cm/s
The estimate for compound 4 lay 1.5-fold (0.18 log units) below the measured number; low and high end bracket the measured number.
By their numbers in this assay, from the lowest: compounds 2, 4 and 3 (each within the scatter of the next); then compound 1.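

In this assay, 4-chloropyridin-3-yl, the only aromatic ring among the groups on this carbonyl carbon and the only one of them with a hydrogen-bond acceptor, could not be told apart from the two chlorine-bearing chains: the step of a 1.1-fold lower number from compound 3 to compound 4 (0.02 log units; within the scatter) and the step of a 1.1-fold higher number from compound 2 to compound 4 (0.04 log units; within the scatter) both lie within the scatter. The step of a 2.2-fold lower number from compound 1 to compound 4 (0.35 log units; beyond the scatter) lies beyond the scatter and is modest, so among these four compounds only compound 1 stands apart, while compounds 2, 3 and 4 form one group whether the chlorine sits on a saturated chain or on an aromatic ring. No measurement at hand speaks to why these three groups read alike.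

Every group here except prop-1-en-1-yl carries a chlorine atom, so the compounds leave open whether the distance of compound 1 from the others goes with the absence of chlorine or with prop-1-en-1-yl itself. They also leave open where a pyridine ring without its chlorine, a longer chain, an amine or a carboxylic acid on this carbonyl carbon would stand in this assay.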